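The source may hold more compounds than are shown below. What is called first, only, known or untested is meant among the compounds shown, and "the series" means these compounds.

Compounds measured so far:
compound 1, `Cc1cc2[nH]nc(N)c2c(=O)[nH]1` — 6%
compound 2, `CC(C)(C)c1cc2[nH]nc(N)c2c(=O)[nH]1` — 22%

The series was tested in an assay on isolated protein for inhibition of ribosomal protein S6 kinase alpha-1 (Homo sapiens), read by mobility shift assay, tested at 30 uM; a higher number here means more inhibition at the concentration tested (going by the name of the read-out), a lower number less inhibition. Compound 1 stands lowest of the two numbers given; its nearest neighbour is compound 2, and the step of a number 16 percentage points higher from compound 1 to compound 2 (beyond the scatter) lies beyond the scatter. For the measured compounds named here, that step, tert-butyl in place of methyl on an aromatic carbon, is the only measured change in this small set.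

Compound 3, `Cc1cc2c(c(N)nn2C)c(=O)[nH]1`, has not yet been measured in this assay. It differs from compound 1 as follows: methyl in place of hydrogen on an aromatic nitrogen. Going by the values given here, this change touches a different part of the shared core than the step from compound 1 to compound 2, so that step does not bear directly on it; no measured pair speaks to a methyl entering on an aromatic nitrogen of the five-membered ring. With nothing to go on, the expectation is a step of a number 1 percentage points lower from compound 1 to compound 3 (within the scatter), which would fall within the scatter, though a loss cannot be ruled out given how low compound 1 already stands. Compound 3 is therefore estimated at 5%, in a range from 0% to 20%.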

Compound 3, a percentage reported as inhibition, at one concentration (the size of the read-out at that concentration, not a potency): 2%
Compound 3: the middle estimate sits 3 percentage points above what was measured, within the range that was stated.
By their numbers in this assay, from the lowest: compounds 3 and 1 (each within the scatter of the next); then compound 2.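

In this assay, for the compounds shown here, the step of a number 4 percentage points lower from compound 1 to compound 3 (within the scatter) gives the first reading at this position, and it shows that hydrogen and methyl on this aromatic nitrogen cannot be told apart at the concentration tested. The step of a number 16 percentage points higher from compound 1 to compound 2 (beyond the scatter) lies beyond the scatter, whereas the methyl on the nitrogen of the five-membered ring leaves the reading within it, so the two places in the shared core do not answer alike to a methyl-sized or larger group in the compounds shown. The reading is weakly informative, however, as compound 1 gives only 6% and leaves little room for any fall to show, and nothing available offers a reason for the result.

From the compounds shown here alone, whether a longer chain such as ethyl, a benzyl group or a chain ending in an amine on this nitrogen would lift the number in this assay remains open. So does whether the methyl on this nitrogen would read the same when the tert-butyl group of compound 2 stands on the aromatic carbon, where the starting number leaves more room to see a fall.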